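Shortening the acyl chain on compound 3

This account rests on a few compounds, and the source may have more. Where it says the series, first, only, none or still open, it means among the compounds named here.

Of the compounds shown here, three that share one core have been tested in a functional assay on the whole organism with Mus musculus as the target, in the rotarod test; a higher number here means that more compound is needed for the effect, a lower number that less compound is needed. Compound 1, `CC(NC(=O)CN)C(=O)N(C)c1ccc(Cl)cc1C(=O)c1ccccc1Cl`, gives 8.5 mg/kg. Compound 2, `CN(C(=O)CNC(=O)CN)c1ccc(Cl)cc1C(=O)c1ccccc1Cl`, gives 27.7 mg/kg. Compound 3, `CCCCC(=O)NCC(=O)N(C)c1ccc(Cl)cc1C(=O)c1ccccc1Cl`, gives 90 mg/kg, the highest of the three numbers: the step is a 3.2-fold higher number from compound 2 to compound 3 (0.51 log units; beyond the scatter) and the step is an 11-fold higher number from compound 1 to compound 3 (1.02 log units; beyond the scatter), so compound 3 needs more compound than either of the others.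

Compound 4, `CCC(=O)NCC(=O)N(C)c1ccc(Cl)cc1C(=O)c1ccccc1Cl`, is the next candidate. Its difference from compound 3 is hydrogen in place of ethyl on a saturated chain carbon, two bonds along the chain from a carbonyl carbon. This shortens the chain that sits on the amide carbonyl; the same difference read one bond further out is butylcarbonyl to propanoyl.

Among the measured steps, only the one that altered this same chain carbon bears on it: a 3.2-fold higher number from compound 2 to compound 3 (0.51 log units; beyond the scatter), where propyl replaced amino. Within the data shown here, no measured pair compares two alkyl chains of different length at this position, so the direction of a shortening is not settled by the data. A modest move is the most that seems warranted. Compound 4 is therefore expected to show a small change, a 1.5-fold lower number from compound 3 to compound 4 (0.18 log units; within the scatter), in this assay, with an estimate of 60 mg/kg and a range from 25 mg/kg to 150 mg/kg.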

Compound 4, dose for half-maximal effect: 36 mg/kg
For compound 4 the middle estimate is 1.7-fold (0.22 log units) above the measured one; the measured number falls inside the stated range.
By their numbers in this assay, from the lowest: compound 1; then compounds 2 and 4 (each within the scatter of the next); then compound 3.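

In this assay, among these compounds, this is the first comparison of two alkyl chains at this chain carbon: going from butylcarbonyl to propanoyl gives a 2.5-fold lower number from compound 3 to compound 4 (0.40 log units; beyond the scatter), so chain length alone moves the number, and here the shorter chain needs less compound. Compound 3 had suggested that an alkyl end in place of amino raises the number, but the methyl end gives a 1.3-fold higher number from compound 2 to compound 4 (0.11 log units; within the scatter), so compound 2 and compound 4 cannot be told apart and an alkyl end does not raise the number in every case. Compound 1 keeps the lowest number of the four, with a 4.2-fold higher number from compound 1 to compound 4 (0.63 log units; beyond the scatter), a step that replaces a larger piece of the chain than the change at this chain carbon alone.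

Among the compounds shown here, only two alkyl chain lengths are compared here, so it remains open whether a still shorter acetyl group would lower the number further, and how a branched isobutyryl group or a carboxylic acid at the chain end would behave. No measurement at hand speaks to why the shorter chain needs less compound.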